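Acylguanidine series: amino analogue of compound 2

The source may hold more compounds than are shown below. What is called first, only, known or untested is meant among the compounds shown, and "the series" means these compounds.

Measured compounds:
compound 1 `Cc1cc(-c2ccc(Cl)cc2)c(S(C)(=O)=O)cc1C(=O)N=C(N)N` 45 nM
compound 2 `Cc1cc(N2CCCCC2)c(S(C)(=O)=O)cc1C(=O)N=C(N)N` 21 nM

In a functional assay for inhibition of sodium/hydrogen exchanger (Oryctolagus cuniculus) (a lower number here means a stronger inhibitor, a higher number a weaker inhibitor), compound 1 gives 45 nM and compound 2 gives 21 nM. Within the data shown here, compound 2 holds the lowest of the two numbers; the only measured step in this assay is a 2.1-fold lower number from compound 1 to compound 2 (0.33 log units; beyond the scatter), a modest but real gain.

Compound 3 `Cc1cc(N)c(S(C)(=O)=O)cc1C(=O)N=C(N)N` differs from compound 2 by amino in place of piperidin-1-yl on an aromatic carbon. Among the measured compounds shown here, the single measured step concerns a different exchange at the same aromatic carbon, a ring for a ring, and does not cover removal of the ring altogether. For the measured compounds named here, no measured pair tells how a group of one heavy atom behaves at this position, so the expectation rests on the size of the only step seen. A step of about that size, in the weakening direction, is expected, a 2.9-fold higher number from compound 2 to compound 3 (0.46 log units; beyond the scatter), with wide uncertainty. Compound 3 is therefore estimated at 60 nM in this assay, within a range of 20 nM to 200 nM.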

Compound 3, half-maximal inhibitory concentration: 16 nM
Beside the measured number, compound 3's estimate is 3.8-fold (0.57 log units) above it; measured number below the stated range.
By their numbers in this assay, from the lowest: compounds 3 and 2 (each within the scatter of the next); then compound 1.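

In this assay this aromatic carbon tolerates loss of the ring: amino in place of piperidin-1-yl gives a 1.3-fold lower number from compound 2 to compound 3 (0.12 log units; within the scatter) and so removes the six-membered ring while staying within the scatter. Against the aryl group, amino in place of 4-chlorophenyl gives a 2.8-fold lower number from compound 1 to compound 3 (0.45 log units; beyond the scatter), so the advantage over compound 1 seen with compound 2 also holds for compound 3, and no ring is required at this position among these three compounds. No evidence on the reason for this tolerance is at hand.

Open, going by these compounds, is whether the hydrogens of the amino group matter here, a question that a dimethylamino or methoxy group on the same carbon would address. Also open, on these data alone, is whether the result holds when the methyl or methylsulfonyl group of the shared core is changed.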